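The compounds below may be only part of what the source reports. "The series", "measured", "known", "first", "only" and "open" are said of these compounds alone.

Measured so far:

Compound 1 `CCCCCCC(C)/C(O)=C1\C(=O)[C@@H]([C@@H](C)O)N(C)C1=O`: in a functional assay on Bel-7402 cells (Homo sapiens) for inhibition, read by MTT assay, with a stated time of 24 h (on this read-out higher numbers stand for weaker inhibition and lower numbers for stronger inhibition), compound 1 gives > 100000 nM, which is a limit of the assay and not a number.
Compound 2 `C/C=C1/C(=O)/C(=C(/O)C(C)CCCCCC)C(=O)N1C`: in this assay compound 2 gives > 100000 nM, likewise a limit of the assay and not a number.

Where compound 2 stands: its value in this assay is the limit of > 100000 nM in this assay, at which 2 of the 2 values shown sit. Among the compounds with values here, both values shown sit at that limit, so the two measured compounds cannot be ordered against each other, and no step between them is available for reading.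

Compound 3 `C/C=C1\C(=O)/C(=C(/O)C(C)CCCCCC)C(=O)N1C` is not yet measured. It differs from compound 2 as follows: the two compounds have the same atoms and bonds; at least one stereo element is drawn with a configuration in one of them and without one in the other: 1 of 3 stereo elements differ; a double bond is drawn Z in compound 2 and E in compound 3. Nothing else moves; the same atoms and bonds are present in both.

Within the data shown here, no measured pair shows what such a change does in this assay. With compound 2 at the limit and no comparison to draw on, the step from compound 2 to compound 3 is expected to be none beyond the scatter, and the most likely outcome is that compound 3 again returns only a limit. The expected step of a number no higher from compound 2 to compound 3 (the limit leaves the size open) is therefore none beyond the scatter. For compound 3 in this assay the estimate is 100000 nM, with a range from 30000 nM to 300000 nM.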

Compound 3, half-maximal inhibitory concentration: > 100000 nM
Compound 3 ended at the assay's limit (the forecaster's own chance of this, stated with the estimate: 80%); the middle value lies on the limit itself.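

In this assay compound 3 gives > 100000 nM, which is a limit of the assay and not a number. No step between compound 2 and compound 3 can be read, because both sit at the same limit: the limit of > 100000 nM in this assay, at which 3 of the 3 values shown sit.

The compounds shown leave open whether the double bond drawn Z in compound 2 and E in compound 3 has any bearing on inhibition in this assay.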